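The source may report more compounds than this note shows. Statements on the series, on what has been measured and on what is new or still open speak of the compounds shown alone.

Measured in a functional assay on B16-F10 cells (Homo sapiens) for cytotoxicity against B16-F10 (Mus musculus), read by MTT assay, with a stated time of 72 h; a lower number here means that less compound is needed, a higher number that more compound is needed for the effect:
Compound 1 `COc1ccc(/C=C2\C(=O)N(c3c(Cl)cccc3Cl)c3ccccc32)cc1OC`: > 100 ug/mL, a limit
Compound 2 `COc1ccc(/C=C2\C(=O)N(c3c(Cl)cccc3Cl)c3ccccc32)cc1`: > 100 ug/mL, a limit

Compound 2 gives no number on which to stand. The value of compound 2 is > 100 ug/mL, which is a limit of the assay. Compound 1 shares this position, and the whole set amounts to the limit of > 100 ug/mL in this assay, at which 2 of the 2 values shown sit.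

Compound 3 `O=C1/C(=C\c2cccc(Cl)c2)c2ccccc2N1c1c(Cl)cccc1Cl` keeps the shared core but carries 3-chlorophenyl in place of 4-methoxyphenyl on a double-bonded chain carbon bound to a double-bonded ring carbon.

Among the measured compounds shown here, only one measured step bears on this change, and only loosely. It is a step that the two limits leave unreadable from compound 1 to compound 2, with hydrogen in place of methoxy on an aromatic carbon, and it has no size to carry over. For the measured compounds named here, no measured step brings in chlorine or replaces the whole aryl group. In this assay, therefore, no step beyond the scatter is expected, and no direction can be argued. The expected step is a number no higher from compound 2 to compound 3 (the limit leaves the size open), held only loosely. For compound 3 the estimate is 100 ug/mL, with an expected range from 30 ug/mL to 300 ug/mL.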

Compound 3, concentration for half-maximal effect: 8 ug/mL
For compound 3 the middle estimate is 13-fold (1.10 log units) above the measured one; measured number below the stated range.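

In this assay the change to 3-chlorophenyl in place of 4-methoxyphenyl on a double-bonded chain carbon bound to a double-bonded ring carbon gives an at least 12-fold lower number from compound 2 to compound 3 (1.09 log units; beyond the scatter). This makes the aryl group at this position the first place among the compounds shown where a change in structure can be read as a change in the assay. The earlier pair could not show this, since the step between compound 1 and compound 2 cannot be read, both values being limits of the assay, and it left open whether any change at this aryl group would register; only compound 3 now stands off that limit: the limit of > 100 ug/mL in this assay, at which 2 of the 3 values shown sit.

The single change takes away the methoxy group and brings in a chlorine at once, so the compounds shown do not separate the loss of the one from the arrival of the other. Also open, on these data alone, is how a 4-chlorophenyl, a 3-methoxyphenyl or a 3-aminophenyl group would read at this same place, and so whether the step belongs to the chlorine itself or to where the group sits on the ring.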